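The source may report more compounds than this note shows. Statements on the series, on what has been measured and on what is new or still open speak of the compounds shown alone.

Working notes on the series. In a functional assay on MDA-MB-231 cells (Homo sapiens) for inhibition, read by MTT assay, with a stated time of 72 h (a higher number here means a weaker inhibitor, a lower number a stronger inhibitor), compound 1 `CO[C@@H]1[C@H]2OC(=O)C[C@H]2O[C@@H]1[C@@H](O)c1ccccc1` gives 35200 nM, and compound 2 `O=C1C[C@H]2O[C@H](C(O)O)[C@H](O)[C@H]2O1` gives 58700 nM. These two values lie within the usual scatter of each other. Compound 3 `CO[C@@H](c1ccccc1)[C@H]1O[C@@H]2CC(=O)O[C@@H]2[C@H]1O` gives 130 nM, a value far lower than that of compound 1 and well beyond the scatter. Compound 1 therefore sits at the weak end of the measured set, level with compound 2 and a long way from compound 3.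

The next compound to be read is compound 4 `CO[C@@H]1[C@H]2OC(=O)C[C@H]2O[C@@H]1[C@H](O)c1ccccc1`. Its change from compound 1 is purely one of configuration: the two compounds have the same atoms and bonds and differ only in configuration as drawn: 1 of 5 stereo elements differ; a stereocentre at a saturated chain carbon is drawn S in compound 1 and R in compound 4. No atom leaves or enters, and the stereocentre at a saturated chain carbon is drawn S in compound 1 and R in compound 4.

Going by the values given here, no measured pair isolates a single change of configuration, so the size of this step has no direct precedent. The expected step of a 1.6-fold lower number from compound 1 to compound 4 (0.20 log units; within the scatter) is none beyond the scatter, with only a slight lean toward a stronger inhibitor. The range is kept wide on the low side, since the series reaches down to compound 3 at 130 nM. For compound 4 the estimated value is 22000 nM, with an expected range of 4000 nM to 70000 nM.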

Compound 4, half-maximal inhibitory concentration: 28600 nM
The estimate for compound 4 lay 1.3-fold (0.11 log units) below the measured number; low and high end bracket the measured number.
By their numbers in this assay, from the lowest: compound 3; then compounds 4, 1 and 2 (each within the scatter of the next, the first and the last beyond it).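

In this assay the series now has its first step that isolates a single change, a 1.2-fold lower number from compound 1 to compound 4 (0.09 log units; within the scatter), and this step shows that redrawing the stereocentre at a saturated chain carbon from S to R gives no separation beyond the scatter. The reading of this step is clean, since no other difference between the pair could mask or add to the outcome: the fact that compounds 1 and 4 differ only in the configuration as drawn. At this position, with the rest of the structure held as in compound 1, configuration alone therefore does not shift the inhibition read-out, and compound 4 at 28600 nM stays in the same range as compound 1 at 35200 nM.

Going by these compounds alone, no measured step connects compound 3, at 130 nM, to compound 1 or compound 4, so what sets its value apart remains unresolved. As far as these compounds go, it also remains open whether this stereocentre would count for more in a compound carrying an amine or a carboxylic acid at the same carbon, as the present pair speaks only for the groups it contains.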